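Changing the distal aryl group of a phosphoserine ester

The compounds below may be only part of what the source reports. "The series", "measured", "known", "first", "only" and "open" are said of these compounds alone.

Compound 1: `Cc1ccccc1Oc1cccc(COc2ccccc2CCC(=O)OCCCOP(=O)(O)OC[C@H](N)C(=O)O)c1`, 0.28
Compound 2: `N[C@@H](COP(=O)(O)OCCCOC(=O)CCc1ccccc1OCc1cccc(Oc2ccc(Cl)cc2)c1)C(=O)O`, 0.76

In an assay on cells for activation of probable G-protein coupled receptor 34 (Mus musculus), with a stated time of 1 h (a lower number here means a smaller maximal response, a higher number a larger maximal response), compound 1 gives 0.28, the lowest of the two numbers; the nearest, compound 2, gives 0.76. Within the data shown here, the only measured step, a number 0.48 higher from compound 1 to compound 2 (beyond the scatter), changes the same aryl group that is altered here and moves the response by a large amount. Compound 3, `CC(C)(C)c1cccc(Oc2cccc(COc3ccccc3CCC(=O)OCCCOP(=O)(O)OC[C@H](N)C(=O)O)c2)c1`, differs from compound 1 by 3-(tert-butyl)phenyl in place of 2-methylphenyl on an oxygen on an aromatic ring. That step is not the one that was measured, so it shows only that the identity of this aryl group can shift the maximal response strongly, without settling the direction for this particular group. Compound 3 is therefore expected to lie between the two measured values, with a step of a number 0.22 higher from compound 1 to compound 3 (beyond the scatter), and its estimated value is 0.5, within a range of 0.2 to 0.85.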

Compound 3, intrinsic activity: the largest response reached, as a fraction of the reference agonist's: 0.39
The estimate for compound 3 lay 0.11 above the measured number, and the stated range covers the measured number.
By their numbers in this assay, from the lowest: compound 1; then compound 3; then compound 2.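

In this assay the 3-(tert-butyl)phenyl group gives only a modest gain over 2-methylphenyl, with a number 0.11 higher from compound 1 to compound 3 (beyond the scatter) as the step, and it falls well short of 4-chlorophenyl, with a number 0.37 lower from compound 2 to compound 3 (beyond the scatter) as the step. The aryl group on this oxygen therefore separates three levels of maximal response among these compounds, and the change to 3-(tert-butyl)phenyl recovers only a small part of the response seen with 4-chlorophenyl. No supporting data bear on why these groups differ.

On these data alone, the three groups differ in both the substituent and its place on the ring, so it remains open which of the two governs the response. A 3-chlorophenyl or 4-(tert-butyl)phenyl group on the same oxygen would separate them, while an unsubstituted phenyl would show the response without any substituent.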